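The source may report more compounds than this note shows. Statements on the series, on what has been measured and on what is new or still open speak of the compounds shown alone.

Measured compounds:
- compound 1, `COc1ccc(C)cc1NC(=S)N/N=C/c1ccc2ccccc2n1`: > 100000 nM, a limit of the assay and not a number
- compound 2, `S=C(N/N=C/c1ccc2ccccc2n1)Nc1cccc(Cl)c1`: 52500 nM
- compound 3, `CC(C)c1cccc(C(C)C)c1NC(=S)N/N=C/c1ccc2ccccc2n1`: 16400 nM

All three share one core and differ only in the group carried on the thiourea nitrogen. In a functional assay on HeLa cells (Homo sapiens) for antiproliferative activity, read by sulforhodamine B assay, with a stated time of 72 h (on this read-out higher numbers stand for weaker inhibition and lower numbers for stronger inhibition), compound 2 gives 52500 nM, which is the higher of the two numbers obtained here. Compound 3, with its 16400 nM, sits lower by a margin beyond the usual scatter of this assay. Compound 1 stands at the limit of > 100000 nM in this assay, at which 1 of the 3 values shown sits, so no number can be set for it and it cannot be placed above or below the others.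

The next compound, compound 4 `S=C(N/N=C/c1ccc2ccccc2n1)Nc1ccccc1Br`, keeps the core and the thiourea link of compound 2 but changes the group on the nitrogen: 2-bromophenyl in place of 3-chlorophenyl on an amide-type nitrogen. The group that leaves and the group that enters are of the same size, each a single six-membered carbon ring bearing one halogen, so a large shift in this assay is not expected. The expected step from compound 2 to compound 4 is a 1.1-fold lower number from compound 2 to compound 4 (0.02 log units; within the scatter), lying within the scatter. Compound 4 is therefore estimated at 50000 nM, with a range from 15000 nM to 150000 nM.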

Compound 4, half-maximal inhibitory concentration: > 100000 nM
Compound 4 was reported as a limit; the forecaster's own chance of this, stated with the estimate: 30%; middle value at least 2.0-fold (0.30 log units) away from the limit.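

Among these compounds, this is the first pair here that differs in one place only, and replacing 3-chlorophenyl with 2-bromophenyl on the amide-type nitrogen gives an at least 1.9-fold higher number from compound 2 to compound 4 (0.27 log units; that floor lies within the scatter). On these data alone, that step is only a floor, so the true size of the change in this assay stays unknown, and the floor alone does not separate the two compounds beyond the scatter. Even a swap between two groups of equal heavy-atom count can therefore end at the top edge of what this read-out can report, where differences can no longer be seen: the limit of > 100000 nM in this assay, at which 2 of the 4 values shown sit.

The change swaps the halogen and its place on the ring in one step, so the compounds shown cannot tell whether the bromine, its position, or both lie behind the result. As far as these compounds go, how this nitrogen would respond to a group of another kind, such as a morpholine ring, a plain ethyl chain, or a phenyl ring carrying a carboxylic acid, also remains open in this assay.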